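Methyl for methoxy on the aryl sulfone of compound 3

The source may hold more compounds than are shown below. What is called first, only, known or untested is meant among the compounds shown, and "the series" means these compounds.

Measured so far in a functional assay (Cavia porcellus) with sulfonylurea receptors; K-ATP channels (Homo sapiens) as the target; on this read-out lower numbers stand for stronger inhibition and higher numbers for weaker inhibition:
compound 1, `CC(O)(C(=O)Nc1ccc(S(=O)(=O)c2cccc(F)c2)cc1)C(F)(F)F`: 3400 nM
compound 2, `CC(O)(C(=O)Nc1ccc(S(=O)(=O)c2ccc(C#N)cc2)cc1)C(F)(F)F`: > 30000 nM
compound 3, `COc1cccc(S(=O)(=O)c2ccc(NC(=O)C(C)(O)C(F)(F)F)cc2)c1`: 16000 nM

The value of compound 2 is a limit of this assay, not a number, (the limit of > 30000 nM in this assay, at which 1 of the 3 values shown sits). Among the numbers, compound 3 gives the highest one; its nearest neighbour is compound 1, with a 4.7-fold higher number from compound 1 to compound 3 (0.67 log units; beyond the scatter). The step from compound 1 to compound 2 reads an at least 8.8-fold higher number from compound 1 to compound 2 (0.94 log units; beyond the scatter), and from compound 2 to compound 3 an at least 1.8-fold lower number from compound 2 to compound 3 (0.27 log units; that floor lies within the scatter).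

Compound 4, `Cc1cccc(S(=O)(=O)c2ccc(NC(=O)C(C)(O)C(F)(F)F)cc2)c1`, differs from compound 3 by methyl in place of methoxy on an aromatic carbon.

Going by the values given here, the only measured step at this aromatic carbon is the one from compound 1 to compound 3, where methoxy in place of fluoro gave a modest rise. Methyl is not fluoro, so a full reversal of that step is not expected; a small move toward a lower number, or none beyond the scatter, is the expectation. Compound 4 is estimated at 9000 nM, between 3500 nM and 22000 nM, which would mean a 1.8-fold lower number from compound 3 to compound 4 (0.25 log units; within the scatter).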

Compound 4, half-maximal inhibitory concentration: 2200 nM
Beside the measured number, compound 4's estimate is 4.1-fold (0.61 log units) above it; the whole stated range lies above it.
By their numbers in this assay, from the lowest: compounds 4 and 1 (each within the scatter of the next); then compound 3. At a limit, above all of these: compound 2.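

In this assay, the change from 3-methoxyphenyl to 3-methylphenyl gives a 7.3-fold lower number from compound 3 to compound 4 (0.86 log units; beyond the scatter), so the earlier rise at this aromatic carbon is now seen against a second group, not only against fluoro. Methyl and fluoro at this carbon do not separate, with a 1.5-fold lower number from compound 1 to compound 4 (0.19 log units; within the scatter), so among the three compounds that differ here, methoxy alone stands apart. The remaining step reads an at least 13-fold lower number from compound 2 to compound 4 (1.13 log units; beyond the scatter), and it is a floor rather than a measured size, as its starting value is a limit: the limit of > 30000 nM in this assay, at which 1 of the 4 values shown sits.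

As far as these compounds go, how an amine or an ethyl group at this aromatic carbon would read stays open. The 4-cyanophenyl of compound 2 has no partner carrying the nitrile elsewhere on the ring, so the group and its place cannot be told apart there.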